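This account rests on a few compounds, and the source may have more. Where it says the series, first, only, none or still open, it means among the compounds named here.

Measured so far:
compound 1, `CCC(C(=O)NC1CC(=O)Nc2c1c(C)nn2-c1ncnc2nc[nH]c12)c1ccccc1`: 79 nM
compound 2, `Cc1cc(C)n(CCOC2CC(=O)Nc3c2c(C)nn3-c2ncnc3nc[nH]c23)n1`: 2000 nM
compound 3, `Cc1cc(C)nc(-n2nc(C)c3c2NC(=O)CC3c2ccc(COc3cccc(Cl)c3)cc2)n1`: 3000 nM

In a functional assay on HEK293 cells for agonist activity at G-protein coupled receptor 39 (Homo sapiens), read by scintillation proximity assay and inositol phosphate accumulation, with a stated time of 75 min (on this read-out higher numbers stand for an effect only at larger amounts of compound and lower numbers for an effect already at smaller amounts), compound 2 gives 2000 nM, the second highest of the three numbers. Compound 3 gives 3000 nM, a value within the scatter of that of compound 2, so no order between the two is drawn. Going by the values given here, compound 1 gives 79 nM, a number beyond the scatter and clearly lower than that of compound 2; no single-point step links these two, so the values are set side by side only. Compound 4, `Cc1nn(-c2ncnc3nc[nH]c23)c2c1C(OCc1ccc(F)cc1)CC(=O)N2`, has not yet been measured. It differs from compound 2 in one place: 4-fluorophenyl in place of (3,5-dimethyl-1H-pyrazol-1-yl)methyl on a saturated chain carbon bound to an oxygen on a saturated carbon. Among the compounds with values here, no step between measured compounds matches this change, so the expectation rests on the numbers above alone. In this assay a modest step toward a lower number is expected, one that may still fall within the scatter. The step from compound 2 to compound 4 is estimated as a 2.2-fold lower number from compound 2 to compound 4 (0.35 log units; beyond the scatter). Compound 4 is estimated at 900 nM, with a range from 250 nM to 3500 nM.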

Compound 4, half-maximal effective concentration: 126 nM
Beside the measured number, compound 4's estimate is 7.1-fold (0.85 log units) above it, outside the stated range (below it).
By their numbers in this assay, from the lowest: compounds 1 and 4 (each within the scatter of the next); then compounds 2 and 3 (each within the scatter of the next).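

In this assay, the group on the oxygen at the saturated carbon proves to be a sensitive point in the series: replacing 2-(3,5-dimethyl-1H-pyrazol-1-yl)ethyl with 4-fluorobenzyl gives a 16-fold lower number from compound 2 to compound 4 (1.20 log units; beyond the scatter). Going by these compounds alone, the earlier compounds differed in more than one place and offered no such reading, so this is the first single-place step, and it is large. No measurement at hand bears on the reason for this step.

The step swaps a five-membered aromatic ring with 2 hetero atoms for a fluorinated carbon-only ring, so the share of the fluorine and that of the ring stay unresolved. A plain benzyl, a 4-chlorobenzyl, a longer chain such as 2-phenylethyl, or an amine on the chain would separate these contributions.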